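Swapping the Chain Amine on a Urea Scaffold

A few compounds are considered here, and "the series" means these few. Any claim that something is new, unique, unknown or untested is made for them only; others in the source may bear on it.

For the measured compounds named here, compound 1 `COc1cc2c(Oc3c(F)cc(NC(=O)NN4C(=O)CCSC4c4c(F)cccc4F)cc3F)ccnc2cc1OCCCN1CCCC1` gives 270 nM in a functional assay on HT-29 cells (Homo sapiens) for antiproliferative activity, read by MTT assay, with a stated time of 72 h (a lower number here means a stronger inhibitor, a higher number a weaker inhibitor), one of only two numbers in hand; compound 2 `COc1cc2c(Oc3c(F)cc(NC(=O)NN4C(=O)CSC4c4c(F)cccc4F)cc3F)ccnc2cc1OCCCN1CCC(N2CCCCC2)CC1` gives 280 nM in this assay, within the scatter of compound 1. Compound 3 `COc1cc2c(Oc3c(F)cc(NC(=O)NN4C(=O)CCSC4c4c(F)cccc4F)cc3F)ccnc2cc1OCCCN1CCC(C)CC1` differs from compound 1 by 4-methylpiperidin-1-yl in place of pyrrolidin-1-yl on a saturated chain carbon, three bonds along the chain from an oxygen on an aromatic ring. Going by the values given here, no measured pair shows this change on its own, so its size is open; a step beyond the scatter is not expected in either direction. Compound 3 is therefore estimated at 250 nM, with a range from 100 nM to 700 nM. That estimate means an expected step of a 1.1-fold lower number from compound 1 to compound 3 (0.03 log units; within the scatter).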

Compound 3, half-maximal inhibitory concentration: 410 nM
Estimate against measurement, compound 3: 1.6-fold (0.21 log units) below; the measured number falls inside the stated range.
By their numbers in this assay, from the lowest: compounds 1, 2 and 3 (each within the scatter of the next).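

In this assay, this first pair differing in one place gives a 1.5-fold higher number from compound 1 to compound 3 (0.18 log units; within the scatter) and so shows that the six-membered 4-methylpiperidin-1-yl can replace the five-membered pyrrolidin-1-yl on this saturated chain carbon without a step beyond the scatter. This holds for this one pair only. No measured evidence bears on the result. From the compounds shown here alone, whether a morpholine ring or an open-chain amine such as dimethylamine would stay within the scatter at this position remains open. So does the effect of a shorter or longer chain carrying the same amine.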